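Benzyl ether aryl variation in the shared core

A few compounds are considered here, and "the series" means these few. Any claim that something is new, unique, unknown or untested is made for them only; others in the source may bear on it.

Measured compounds in a functional assay on MCF7 cells (Homo sapiens) for antiproliferative activity, read by sulforhodamine B assay, with a stated time of 72 h; a lower number here means a stronger inhibitor, a higher number a weaker inhibitor:
- compound 1 `Cc1ccccc1COc1ccc(-c2cc(CN3CCN(Cc4ccc(C(F)(F)F)cc4)CC3)no2)cc1`: 3700 nM
- compound 2 `Cc1ccc(COc2ccc(-c3cc(CN4CCN(Cc5ccc(C(F)(F)F)cc5)CC4)no3)cc2)cc1`: 1200 nM
- compound 3 `Fc1ccc(COc2ccc(-c3cc(CN4CCN(Cc5ccc(C(F)(F)F)cc5)CC4)no3)cc2)cc1`: 7900 nM

Compound 3 gives the highest number of the three, so it is the weakest inhibitor in this set; its nearest neighbour is compound 1 and the furthest is compound 2, both steps beyond the scatter. The change considered here is 3,4,5-trimethoxyphenyl in place of 4-fluorophenyl on a saturated chain carbon bound to an oxygen on an aromatic ring, giving compound 4 `COc1cc(COc2ccc(-c3cc(CN4CCN(Cc5ccc(C(F)(F)F)cc5)CC4)no3)cc2)cc(OC)c1OC`.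

All three measured steps vary the same aryl group on the benzyl ether, so all bear on this step. Going from the 2-methyl to the 4-methyl pattern gave a 3.1-fold lower number from compound 1 to compound 2 (0.49 log units; beyond the scatter); swapping methyl for fluoro gave a 6.6-fold higher number from compound 2 to compound 3 (0.82 log units; beyond the scatter); and the direct comparison gave a 2.1-fold higher number from compound 1 to compound 3 (0.33 log units; beyond the scatter). The aryl group therefore moves this assay by modest but real amounts, and compound 3 sits at the weak end of what this position has shown. The trimethoxy aryl is a larger departure than any measured swap, so direction is uncertain; a modest step toward lower numbers, partly recovering the level of compound 2, is the most defensible expectation, with wide bounds.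

For compound 4 the expected step is a 2.6-fold lower number from compound 3 to compound 4 (0.42 log units; beyond the scatter). Compound 4 is estimated at 3000 nM, with a range from 800 nM to 12000 nM.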

Compound 4, half-maximal inhibitory concentration: 1800 nM
For compound 4 the middle estimate is 1.7-fold (0.22 log units) above the measured one; measured number inside the range.
By their numbers in this assay, from the lowest: compounds 2 and 4 (each within the scatter of the next); then compound 1; then compound 3.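

In this assay the position on a saturated chain carbon bound to an oxygen on an aromatic ring accepts the larger 3,4,5-trimethoxyphenyl group, and replacing 4-fluorophenyl gives a 4.4-fold lower number from compound 3 to compound 4 (0.64 log units; beyond the scatter) at this position. Against the 4-methylphenyl group the same aryl group gives a 1.5-fold higher number from compound 2 to compound 4 (0.18 log units; within the scatter) and so cannot be told apart from it here, while against the 2-methylphenyl group it gives a 2.1-fold lower number from compound 1 to compound 4 (0.31 log units; beyond the scatter) in this series. The low end of the range at this position is therefore shared by a singly substituted and a triply substituted phenyl group, with 4-fluorophenyl still at the high end, and nothing at hand explains this ordering.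

Open, from the compounds shown here alone, is how much of the trimethoxy result depends on having all three methoxy groups, as a single methoxy group or an unsubstituted phenyl would help to show. Also open, going by these compounds, is whether an amine or a carboxylic acid on this aryl group would stay at the level shared by compound 2 and compound 4 or move toward the level of compound 3.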